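A few compounds are considered here, and "the series" means these few. Any claim that something is new, unique, unknown or untested is made for them only; others in the source may bear on it.

Within the data shown here, compound 3 `Cc1nn(C)c(Oc2cccc(Cl)c2)c1/C=N\CCCCCCOc1cc2oc(=O)cc(C)c2cc1Cl` stands lowest of the three numbers so far: in a functional assay on HepG2 cells (Homo sapiens) for antiproliferative activity, read by MTT assay, with a stated time of 72 h (on this read-out lower numbers stand for stronger inhibition and higher numbers for weaker inhibition), compound 3 gives 6220 nM, whereas compound 2 `Cc1nn(C)c(Oc2ccc(Br)cc2)c1/C=N\CCCCCOc1cc2oc(=O)cc(C)c2cc1Cl` gives 13800 nM and compound 1 `Cc1nn(C)c(Oc2ccc(Cl)cc2)c1/C=N\CCCCCOc1cc2oc(=O)cc(C)c2cc1Cl` gives 15300 nM. Among the measured compounds shown here, the only measured single step, a 1.1-fold lower number from compound 1 to compound 2 (0.04 log units; within the scatter), exchanged one halogen for another on the phenoxy ring and left the read-out essentially unchanged. Compound 4 `Cc1ccccc1Oc1c(/C=N\CCCCCCOc2cc3oc(=O)cc(C)c3cc2Cl)c(C)nn1C` differs from compound 3 by 2-methylphenyl in place of 3-chlorophenyl on an oxygen on an aromatic ring. For the measured compounds named here, no measured step exchanges chloro for methyl on this ring, so the halogen swap is only a loose guide; it hints that changes on this ring move the number little. The step is expected to stay small, a 1.1-fold higher number from compound 3 to compound 4 (0.05 log units; within the scatter). The estimate for compound 4 is 7000 nM, with a range from 3000 nM to 16000 nM.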

Compound 4, half-maximal inhibitory concentration: 7830 nM
Compound 4: middle estimate off by 1.1-fold (0.05 log units), on the low side; low and high end bracket the measured number.
By their numbers in this assay, from the lowest: compounds 3, 4, 2 and 1 (each within the scatter of the next, the first and the last beyond it).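

The exchange of 3-chlorophenyl for 2-methylphenyl on an oxygen on an aromatic ring gives a 1.3-fold higher number from compound 3 to compound 4 (0.10 log units; within the scatter) and so stays within the scatter. Unlike the earlier swap of one halogen for another, this step replaces chloro with a carbon group and also alters the group's printed ring position, yet compound 3 and compound 4 cannot be told apart. No available evidence explains this result. On these data alone, it remains open whether an amine or a carboxylic acid on this ring would move the number beyond the scatter. The separate effects of exchanging the group and moving it also remain unresolved, as 3-methylphenyl is not among the compounds shown.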